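The source may hold more compounds than are shown below. What is called first, only, known or untested is meant among the compounds shown, and "the series" means these compounds.

Measured compounds:
compound 1 `COc1ccc(Nc2cccc3c(C)c(C)sc23)cc1OC`, 100%
compound 2 `COc1ccc(Nc2cccc3c(C)c(C)sc23)cc1`, 100%

In a functional assay for inhibition, with a stated time of 2 h, tested at 0.250 g/L (on this read-out lower numbers stand for less inhibition and higher numbers for more inhibition at the one concentration tested (going by the name of the read-out)), compound 1 gives 100%. Compound 2, which carries hydrogen in place of methoxy on an aromatic carbon, gives in this assay 100%. Within the data shown here, the step of no change at the digits printed from compound 1 to compound 2 (within the scatter) is the only measured step, and it shows that removing one of the two methoxy groups from compound 1 leaves the read-out unchanged within the scatter. On the numbers shown, compound 1 stands level with compound 2, both at the top of the scale this read-out can report, so neither number can be called higher or lower than the other.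

Compound 3 `COc1cccc(Nc2cccc3c(C)c(C)sc23)c1` is not yet measured. It differs from compound 1 by hydrogen in place of methoxy on an aromatic carbon. The step from compound 1 to compound 2 bears on this change directly, since it is the same kind of replacement, and it was without effect beyond the scatter. The expectation is therefore a step of a number 3 percentage points lower from compound 1 to compound 3 (within the scatter) of no size beyond the scatter, in no particular direction. Compound 3 is estimated at 97%, in the range 85% to 100%.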

Compound 3, a percentage reported as inhibition, at one concentration (the size of the read-out at that concentration, not a potency): 84.8%
Estimate against measurement, compound 3: 12.2 percentage points above; the whole stated range lies above it.
By their numbers in this assay, from the lowest: compound 3; then compounds 1 and 2 (each within the scatter of the next).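

In this assay, replacing with hydrogen the methoxy group that stands para to a large group and ortho to a methoxy group gives a number 15.2 percentage points lower from compound 1 to compound 3 (beyond the scatter). The same kind of replacement at the other methoxy group gave no change at the digits printed from compound 1 to compound 2 (within the scatter), so the two methoxy groups of compound 1 cannot be treated as interchangeable in this read-out, although the present step is modest and rests on a single concentration. No measurement here bears on the reason for this difference.

Compound 1 and compound 2 both sit at the top of the scale of this assay, so any loss that these two compounds might hide at this concentration stays out of view. On these data alone, it remains open how this carbon would respond to a group other than methoxy or hydrogen, such as a hydroxyl group, an amine or a longer alkoxy chain, and whether the step seen here would persist at a lower concentration, where the read-out would not be held at its upper end.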